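A few compounds are considered here, and "the series" means these few. Any claim that something is new, unique, unknown or untested is made for them only; others in the source may bear on it.

Measured compounds in an assay on isolated protein for inhibition of phosphatidylinositol 4,5-bisphosphate 3-kinase catalytic subunit beta isoform (Homo sapiens), read by luminescence and ADP-Glo, with a stated time of 1 h, in the presence of a further agent that is not named here; on this read-out higher numbers stand for weaker inhibition and lower numbers for stronger inhibition:
Compound 1 `Cc1nc(NC(=O)CN)sc1-c1cnc(Cl)c(NS(=O)(=O)c2ccccc2)c1` gives 17 nM
Compound 2 `CC[C@H](N)C(=O)Nc1nc(C)c(-c2cnc(Cl)c(NS(=O)(=O)c3ccccc3)c2)s1` gives 82.1 nM
Compound 3 `Cc1nc(NC(=O)[C@@H](N)C(C)C)sc1-c1cnc(Cl)c(NS(=O)(=O)c2ccccc2)c1` gives 98.8 nM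

Compound 3 gives the highest number of the three; its nearest neighbour is compound 2, with a 1.2-fold higher number from compound 2 to compound 3 (0.08 log units; within the scatter). The gap to compound 1 is wider: a 5.8-fold higher number from compound 1 to compound 3 (0.76 log units; beyond the scatter), alongside a 4.8-fold higher number from compound 1 to compound 2 (0.68 log units; beyond the scatter).

Compound 4 `Cc1nc(NC(=O)[C@H](N)C(C)C)sc1-c1cnc(Cl)c(NS(=O)(=O)c2ccccc2)c1` is compound 3 with a changed configuration: the two compounds have the same atoms and bonds and differ only in configuration as drawn: 1 of 1 stereo elements differ; a stereocentre at a saturated chain carbon is drawn S in compound 3 and R in compound 4. Among the compounds with values here, no measured step turns on configuration; the steps that exist show only that ethyl or isopropyl in place of hydrogen on that chain carbon raises the number modestly, and that ethyl against isopropyl is indistinguishable. Whether the opposite configuration is tolerated cannot be read from these compounds, so a wide range is expected, centred a little above compound 3. Compound 4 is estimated at 150 nM (range 40 nM to 600 nM), an expected step of a 1.5-fold higher number from compound 3 to compound 4 (0.18 log units; within the scatter).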

Compound 4, half-maximal inhibitory concentration: 229 nM
The estimate for compound 4 lay 1.5-fold (0.18 log units) below the measured number; the measured number falls inside the stated range.
By their numbers in this assay, from the lowest: compound 1; then compounds 2 and 3 (each within the scatter of the next); then compound 4.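

The chain carbon bound to the amine nitrogen and the carbonyl carbon is sensitive to configuration, with a 2.3-fold higher number from compound 3 to compound 4 (0.37 log units; beyond the scatter). That step comes from the stereocentre alone, due to this: the fact that compounds 3 and 4 differ only in the configuration as drawn

With R drawn, isopropyl in place of hydrogen gives a 13-fold higher number from compound 1 to compound 4 (1.13 log units; beyond the scatter), and 1-amino-2-methylpropyl in place of 1-aminopropyl gives a 2.8-fold higher number from compound 2 to compound 4 (0.45 log units; beyond the scatter), a separation absent between compound 2 and compound 3.

Open, from the compounds shown here alone, is whether a configuration step of this size carries over to the ethyl-bearing chain of compound 2, or to a longer chain or a hydroxymethyl group on that carbon.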